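Trading Fluorine for Methyl on a Cyclopropyl Amide

This account rests on a few compounds, and the source may have more. Where it says the series, first, only, none or still open, it means among the compounds named here.

Three amides built on one shared core have been measured in an assay on CHO cells for displacement of a labelled ligand from Neuronal acetylcholine receptor; alpha3/alpha6/beta2/beta3 (Homo sapiens), read by scintillation counting; a higher number here means a weaker inhibitor, a lower number a stronger inhibitor. Compound 1 `CC(C)C(=O)N1CC2CC(C1)N2`, with an isopropyl group on its carbonyl carbon, gives 580 nM. Compound 2 `O=C(CC1C=CCC1)N1CC2CC(C1)N2` gives 2500 nM. Compound 3 `O=C([C@H]1C[C@H]1F)N1CC2CC(C1)N2` gives 27 nM, the lowest number of the three; compound 1 sits nearest to it and compound 2 furthest, both gaps beyond the scatter. Among the measured compounds shown here, the only single-point step among the measured compounds is a 21-fold lower number from compound 1 to compound 3 (1.33 log units; beyond the scatter), a large gain.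

Compound 4 `C[C@H]1C[C@@H]1C(=O)N1CC2CC(C1)N2` has not yet been measured. It differs from compound 3 in one place: 2-methylcyclopropyl in place of 2-fluorocyclopropyl on a carbonyl carbon. The fluorine of the 2-fluorocyclopropyl is thus traded for the methyl of the 2-methylcyclopropyl, the three-membered ring itself staying. For the measured compounds named here, only the step from compound 1 to compound 3 bears on this, and only in part: it shows that the fluorinated cyclopropyl amide beats the isopropyl amide, but it cannot separate what the ring contributes from what the fluorine contributes. Compound 2 offers no guidance on a cyclopropyl. Because a 21-fold lower number from compound 1 to compound 3 (1.33 log units; beyond the scatter) was obtained with the three-membered ring present and compound 4 keeps that ring, compound 4 is expected to hold much of that gain while giving some back, an expected step of a 3.0-fold higher number from compound 3 to compound 4 (0.47 log units; beyond the scatter). The estimate for compound 4 in this assay is 80 nM, with a range from 20 nM to 320 nM.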

Compound 4, inhibition constant: 310 nM
Compound 4: the middle estimate sits 3.9-fold (0.59 log units) below what was measured; the measured number falls inside the stated range.
By their numbers in this assay, from the lowest: compound 3; then compounds 4 and 1 (each within the scatter of the next); then compound 2.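

Keeping the three-membered ring and the heavy-atom count unchanged while replacing fluorine with methyl gives an 11-fold higher number from compound 3 to compound 4 (1.06 log units; beyond the scatter) in this assay, so the ring alone does not account for the low number of compound 3. The isopropyl comparison gives a 1.9-fold lower number from compound 1 to compound 4 (0.27 log units; within the scatter), which lies within the scatter, so this assay does not separate 2-methylcyclopropyl from isopropyl on this carbonyl carbon. Among these compounds, the large gain therefore goes with the 2-fluorocyclopropyl group rather than with any cyclopropyl ring, although nothing available here explains the difference between the fluorine and the methyl.

From the compounds shown here alone, it remains open whether a plain cyclopropyl group, carrying neither fluorine nor methyl, would give a number closer to that of compound 3 or compound 4, and whether a 2-chlorocyclopropyl or 2,2-difluorocyclopropyl group would keep the gain. Also unresolved is how much the result depends on the particular arrangement at the two defined stereocentres, since the compounds shown do not compare the same group with its stereocentres arranged differently.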